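Does the Same Small Change Carry to a Second Core?

This account rests on a few compounds, and the source may have more. Where it says the series, first, only, none or still open, it means among the compounds named here.

In a functional assay on cells for antagonist activity at Orexin receptor type 2 (Homo sapiens), read by fluorescence and calcium flux, with a stated time of 30 min (on this read-out lower numbers stand for stronger inhibition and higher numbers for weaker inhibition), compound 1 `CCN(C(=O)c1cc(C)ccc1-n1nccn1)[C@@H](C)Cn1ccc(-c2ccc(F)cn2)n1` gives 1.61 nM.
In this assay compound 2 `Cc1ccc(-n2nccn2)c(C(=O)N(C)[C@@H](C)Cn2ccc(-c3ccc(F)cn3)n2)c1` gives 5.68 nM.
In this assay compound 3 `Cc1ccc(-n2nccn2)c(C(=O)N(C)[C@@H](C)Cn2cc(-c3ccc(F)cn3)cn2)c1` gives 21.2 nM.

Compound 2 and compound 3 are built from the same atoms joined differently; the difference between the two cores is not broken down here. Compound 3 gives the highest number of the three, and its gaps to compound 2 and to compound 1 both lie beyond the scatter. Compound 1 and compound 2 share one core and differ in one place: methyl in place of hydrogen on a saturated chain carbon bound to an amide-type nitrogen. That single change produced a 3.5-fold lower number from compound 2 to compound 1 (0.55 log units; beyond the scatter).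

Compound 4 `CCN(C(=O)c1cc(C)ccc1-n1nccn1)[C@@H](C)Cn1cc(-c2ccc(F)cn2)cn1` is related to compound 3 in exactly the same way: methyl in place of hydrogen on a saturated chain carbon bound to an amide-type nitrogen. The place of the change is the same in both pairs, so this is the same change, applied on the core of compound 3 instead of the core of compound 2.

Since the change is identical and each core carries the same other groups, the step from compound 3 to compound 4 is expected to be about a 3.5-fold lower number from compound 3 to compound 4 (0.55 log units; beyond the scatter), resting on the measured 3.5-fold lower number from compound 2 to compound 1 (0.55 log units; beyond the scatter). The estimate for compound 4 is 6 nM, expected to fall between 2.5 nM and 15 nM.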

Compound 4, half-maximal inhibitory concentration: 5.87 nM
Estimate against measurement, compound 4: 1.0-fold (0.01 log units) above, and the stated range covers the measured number.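

In this assay the change of methyl to ethyl gave a 3.6-fold lower number from compound 3 to compound 4 (0.56 log units; beyond the scatter), and set beside the earlier step on the other core, it kept almost exactly the same size: the same change on two cores in this assay, a 3.5-fold lower number (0.55 log units; beyond the scatter) from compound 2 to compound 1 and a 3.6-fold lower number (0.56 log units; beyond the scatter) from compound 3 to compound 4, 1.0-fold (0.01 log units) apart, within the scatter of two such steps

So within these two pairs, the step measured on the core of compound 2 was a reliable guide to the step on the core of compound 3, and the two cores can be treated as adding up independently of this change. This rests on one change, two cores and one assay, so it does not show that the step would hold on any further core, and it gives no reason for why the number falls.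

Still open, from the compounds shown here alone, is whether the trend continues with a longer chain such as propyl, or with a branched chain such as isopropyl, at the same place. A chain ending in a hydroxyl group or an amine might also behave differently, and whether it would do so equally on both cores cannot be told from these four compounds.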